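Fluorines on the N-aryl ring of the triazole series

The compounds below may be only part of what the source reports. "The series", "measured", "known", "first", "only" and "open" are said of these compounds alone.

Measured so far:
- compound 1, `Cc1c(C(=O)Nc2ccc(Oc3ccnc4[nH]ccc34)c(F)c2)nnn1-c1ccccc1`: 290 nM
- compound 2, `Cc1c(C(=O)Nc2ccc(Oc3ccnc4[nH]ccc34)cc2)nnn1-c1ccccc1`: 350 nM

Both compounds were run in a functional assay on HT-29 cells (Homo sapiens) for cytotoxicity, read by MTT assay, with a stated time of 72 h; on this read-out higher numbers stand for weaker inhibition and lower numbers for stronger inhibition. Among the compounds with values here, compound 2 gives the highest of the two numbers, with compound 1 as its nearest neighbour; the only step between them, a 1.2-fold higher number from compound 1 to compound 2 (0.08 log units; within the scatter), lies within the scatter, so the two cannot be ordered.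

Compound 3, `Cc1c(C(=O)Nc2ccc(Oc3ccnc4[nH]ccc34)cc2)nnn1-c1ccc(F)c(F)c1`, is not yet measured. It differs from compound 2 in one place: 3,4-difluorophenyl in place of phenyl on an aromatic nitrogen. Within the data shown here, no measured step touches this ring; the single known step concerns fluoro on the anilide ring, and it changed nothing beyond the scatter. The data therefore give no reason to expect a step from compound 2 to compound 3 that is larger than the scatter, in either direction, though a second aryl ring carrying two fluorines is an untested change and the range is kept wide.

For compound 3 in this assay the expected step is a 1.3-fold lower number from compound 2 to compound 3 (0.13 log units; within the scatter), and the expected value is 260 nM, with a range from 80 nM to 900 nM.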

Compound 3, half-maximal inhibitory concentration: 1070 nM
The estimate for compound 3 lay 4.1-fold (0.61 log units) below the measured number, outside the stated range (above it).
By their numbers in this assay, from the lowest: compounds 1 and 2 (each within the scatter of the next); then compound 3.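

Of the steps shown, the only one beyond the scatter falls at the aryl group on the aromatic nitrogen: in this assay, 3,4-difluorophenyl in place of phenyl gives a 3.1-fold higher number from compound 2 to compound 3 (0.49 log units; beyond the scatter), a move towards weaker inhibition. The fluoro change elsewhere in the molecule, a 1.2-fold higher number from compound 1 to compound 2 (0.08 log units; within the scatter), stays within the scatter, so the result for that change does not carry over to this position, and this aryl group cannot be treated as free to vary with fluorines. Nothing available bears on why the number rises at this position.

From the compounds shown here alone, this reading rests on a single pair, so it remains open whether the step needs both fluorines or whether a monofluorophenyl group would already give it, and whether the fluorine at one ring carbon counts for more than the other. Also open, going by these compounds, is how this position responds to groups other than fluoro, such as a methoxy or an amine on the phenyl ring, or to a cyclohexyl group in place of the aryl ring.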